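The source may hold more compounds than are shown below. What is called first, only, known or untested is meant among the compounds shown, and "the series" means these compounds.

Of the compounds shown here, three built on one shared core have been tested in an ADME assay on Huh-7 cells (Homo sapiens) for cytotoxicity; on this read-out higher numbers stand for lower toxicity in this test and lower numbers for higher toxicity in this test. Compound 1 `O=C(NC(=S)n1ccc2c(OCCCCCOc3ccc(Cl)cc3)cccc21)c1ccccc1` gives 29500 nM. Compound 2 `O=C(NC(=S)N1CCc2c(OCCCCCOc3ccc(Cl)cc3)cccc21)c1cccc([N+](=O)[O-])c1` gives 12100 nM, and compound 3 `O=C(NC(=S)N1CCc2c(OCCCCCOc3ccc(Cl)cc3)cccc21)c1ccc([N+](=O)[O-])cc1` gives 13600 nM. Of these three numbers, that of compound 2 is the lowest on paper, yet compound 3 lies within the scatter of it; only compound 1 stands beyond the scatter, with a higher number. The step to compound 4 `CC(C)(C)c1ccc(C(=O)NC(=S)N2CCc3c(OCCCCCOc4ccc(Cl)cc4)cccc32)cc1` changes one place on compound 2: 4-(tert-butyl)phenyl in place of 3-nitrophenyl on a carbonyl carbon. Among the measured compounds shown here, the one measured step of the same kind swaps one nitrophenyl for another: a 1.1-fold higher number from compound 2 to compound 3 (0.05 log units; within the scatter). For the measured compounds named here, no measured step speaks to a 4-(tert-butyl)phenyl group, so no step beyond the scatter is expected. Compound 4 is therefore estimated at about 13000 nM in this assay, between 5000 nM and 35000 nM. That estimate means an expected step of a 1.1-fold higher number from compound 2 to compound 4 (0.03 log units; within the scatter).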

Compound 4, half-maximal cytotoxic concentration: > 50000 nM
Compound 4 ended at the assay's limit (the forecaster's own chance of this, stated with the estimate: 10%); middle value at least 3.8-fold (0.58 log units) away from the limit.
By their numbers in this assay, from the lowest: compounds 2 and 3 (each within the scatter of the next); then compound 1. At a limit, above all of these: compound 4.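

Swapping one nitrophenyl for the other on this carbonyl carbon gave no step beyond the scatter, but the 4-(tert-butyl)phenyl group does give one (an at least 4.1-fold higher number from compound 2 to compound 4 (0.61 log units; beyond the scatter)) (an at least 3.6-fold higher number from compound 3 to compound 4 (0.56 log units; beyond the scatter)). The group at this place can therefore shift the read-out towards lower toxicity in this test. Compound 4 stands at a limit of the assay, not at a number, so both steps are minimum sizes.

From the compounds shown here alone, it remains open whether a smaller group on that phenyl ring, such as methyl or an amine, would shift the read-out as well.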